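Three Limits and a Smaller Group on the Aryl Ring

The compounds below may be only part of what the source reports. "The series", "measured", "known", "first", "only" and "open" are said of these compounds alone.

In a functional assay on KYSE-410 cells (Homo sapiens) for antiproliferative activity, read by MTT assay, with a stated time of 72 h (a lower number here means a stronger inhibitor, a higher number a weaker inhibitor), compound 1 (`O=C(Nc1ccc(F)cc1)c1cc(=O)[nH]c2cc(Br)ccc12`) gives > 20000 nM as a limit of the assay and not a number. Compound 2 (`O=C(Nc1cc(F)cc(F)c1)c1cc(=O)[nH]c2cc(F)ccc12`) likewise gives > 20000 nM as a limit. Compound 3 (`CC(C)(C)c1ccc(-c2ccc3c(C(=O)Nc4cccc(F)c4)cc(=O)[nH]c3c2)cc1`) also gives only a limit, > 20000 nM in the same read-out. The whole set therefore stands at the limit of > 20000 nM in this assay, at which 3 of the 3 values shown sit, and so far offers no measured number, and compound 3 has no numerical position within it.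

Compound 4 (`Cc1ccc(-c2ccc3c(C(=O)Nc4cccc(F)c4)cc(=O)[nH]c3c2)cc1`) differs from compound 3 in a single place, with methyl in place of tert-butyl on an aromatic carbon on a six-membered aromatic ring of carbon only, para to a large group. The change is a move from 4-(tert-butyl)phenyl to 4-methylphenyl.

Going by the values given here, no step between measured compounds is available to size this change in this assay, so only a modest gain toward stronger inhibition is expected, and quite possibly none that can be seen. This expectation rests on compound 3, whose limit of > 20000 nM leaves no number to start from. The expected size of the step of an at least 1.3-fold lower number from compound 3 to compound 4 (0.12 log units; that floor lies within the scatter) is small and its direction is toward a lower number. For compound 4 the estimated half-maximal inhibitory concentration is 15000 nM within an expected range of 6000 nM to 20000 nM in this read-out.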

Compound 4, half-maximal inhibitory concentration: > 20000 nM
Compound 4: a limit, no number; the forecaster's own chance of this, stated with the estimate: 60%; middle value at least 1.3-fold (0.12 log units) from the limit.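

In this assay compound 4 gives > 20000 nM, a limit of the assay and not a number. Going by these compounds alone, compound 3 also stands at a limit, and no step between compound 3 and compound 4 can be read. The compounds shown leave open whether methyl or tert-butyl makes any difference, and what number any of them would reach: the limit of > 20000 nM in this assay, at which 4 of the 4 values shown sit.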